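Para-Substituent Swap on the Phenyltriazole Tail

This account rests on a few compounds, and the source may have more. Where it says the series, first, only, none or still open, it means among the compounds named here.

Three analogues share one core in which a diaryl urea is tethered through an ether to an aryl-triazole. Compound 1 `O=C(Nc1cccc(OCc2cn(-c3ccccc3)nn2)c1)Nc1ccc(Cl)c(C(F)(F)F)c1` gives 1780 nM in a functional assay on HepG2 cells (Homo sapiens) for inhibition, read by MTT assay, with a stated time of 72 h; on this read-out higher numbers stand for weaker inhibition and lower numbers for stronger inhibition. Compound 2 `Cc1ccc(-n2cc(COc3cccc(NC(=O)Nc4ccc(Cl)c(C(F)(F)F)c4)c3)nn2)cc1` gives 5430 nM in this assay, and compound 3 `N#Cc1ccc(-n2cc(COc3cccc(NC(=O)Nc4ccc(Cl)c(C(F)(F)F)c4)c3)nn2)cc1` gives 2980 nM, placing compound 3 second highest of the three numbers, closer to compound 1 than to compound 2. The step of a 3.1-fold higher number from compound 1 to compound 2 (0.48 log units; beyond the scatter) is the only one beyond the scatter; a 1.7-fold higher number from compound 1 to compound 3 (0.22 log units; within the scatter) and a 1.8-fold lower number from compound 2 to compound 3 (0.26 log units; within the scatter) both stay within it.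

Compound 4 `CCc1ccc(-n2cc(COc3cccc(NC(=O)Nc4ccc(Cl)c(C(F)(F)F)c4)c3)nn2)cc1` differs from compound 3 by ethyl in place of cyano on an aromatic carbon. The nearest guide is the cyano-to-methyl comparison, and reversing a 1.8-fold lower number from compound 2 to compound 3 (0.26 log units; within the scatter) suggests a higher number for compound 4, though that reversed step is itself small; the larger 3.1-fold higher number from compound 1 to compound 2 (0.48 log units; beyond the scatter) hints that an alkyl group here tends toward weaker inhibition. Compound 4 is therefore expected to show a 1.5-fold higher number from compound 3 to compound 4 (0.18 log units; within the scatter), a modest rise, with an estimated 4500 nM in this assay, ranging from 2000 nM to 10000 nM.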

Compound 4, half-maximal inhibitory concentration: 1950 nM
For compound 4 the middle estimate is 2.3-fold (0.36 log units) above the measured one, outside the stated range (below it).
By their numbers in this assay, from the lowest: compounds 1, 4, 3 and 2 (each within the scatter of the next, the first and the last beyond it).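

At this position in this assay, ethyl does not continue the rise seen with methyl: going from methyl to ethyl gives a 2.8-fold lower number from compound 2 to compound 4 (0.44 log units; beyond the scatter), a step beyond the scatter. Ethyl in place of hydrogen gives a 1.1-fold higher number from compound 1 to compound 4 (0.04 log units; within the scatter) and ethyl in place of cyano gives a 1.5-fold lower number from compound 3 to compound 4 (0.18 log units; within the scatter), so hydrogen, cyano and ethyl cannot be told apart here. Among these four compounds an alkyl group therefore does not by itself go with weaker inhibition: compound 2 lies beyond the scatter of compound 1, whereas compound 4 does not.

No evidence is available that accounts for methyl standing apart from ethyl. Going by these compounds, whether a propyl chain, a methoxy group, an amine or a carboxylic acid at this position would fall with compound 2 or with compound 1 remains open.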